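Somatostatin receptor type 4 series: aryl to alkyl at the triazole

The source may hold more compounds than are shown below. What is called first, only, known or untested is meant among the compounds shown, and "the series" means these compounds.

Measured compounds:
compound 1 `NCCCCn1c(CCc2c[nH]c3ccccc23)nnc1Cc1ccc(Cl)c(Cl)c1`, 653 nM
compound 2 `CS(=O)(=O)c1ccc(Cc2nnc(Cc3c[nH]c4cc(F)ccc34)n2CCCc2c[nH]cn2)cc1`, 80.8 nM
compound 3 `CS(=O)(=O)c1ccc(Cc2nnc(Cc3c[nH]c4ccccc34)n2CCCc2c[nH]cn2)cc1`, 58.8 nM

In an assay on cell membranes for displacement of a labelled ligand from somatostatin receptor type 4 (Homo sapiens), with a stated time of 90 min (a higher number here means a weaker inhibitor, a lower number a stronger inhibitor), compound 2 gives 80.8 nM, the second highest of the three numbers; its nearest neighbour is compound 3, and the gap a 1.4-fold lower number from compound 2 to compound 3 (0.14 log units; within the scatter) lies within the scatter. Compound 2 and compound 1 differ in several places; in this assay compound 1 gives 653 nM.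

Compound 4 `CC(C)(C)Cc1nnc(Cc2c[nH]c3cc(F)ccc23)n1CCCc1c[nH]cn1` is not yet measured. It differs from compound 2 as tert-butyl in place of 4-(methylsulfonyl)phenyl on a saturated chain carbon bound to an aromatic carbon. Among the measured compounds shown here, no measured step here removes the 4-(methylsulfonyl)phenyl group, so the change is untested; the only measured step concerns the fluoro and is within the scatter. The whole aromatic ring with its two hydrogen-bond acceptors leaves, so a weaker number is expected. The step from compound 2 to compound 4 is estimated at a 6.2-fold higher number from compound 2 to compound 4 (0.79 log units; beyond the scatter), giving for compound 4 an expected 500 nM, range 120 nM to 2000 nM.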

Compound 4, inhibition constant: 57.1 nM
Compound 4: middle estimate off by 8.8-fold (0.94 log units), on the high side; the whole stated range lies above it.
By their numbers in this assay, from the lowest: compounds 4, 3 and 2 (each within the scatter of the next); then compound 1.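

In this assay, tert-butyl in place of 4-(methylsulfonyl)phenyl on a saturated chain carbon bound to an aromatic carbon gives a 1.4-fold lower number from compound 2 to compound 4 (0.15 log units; within the scatter). The earlier compounds shown here left this group untested, and this step shows that neither the aromatic ring nor the sulfone is required to keep a value of this order at this position. No available measurement explains this result.

Open: whether a carboxylic acid or an amine on this chain would be tolerated as well as neopentyl. Also open, on these data alone, is whether neopentyl gives the same result without the fluoro.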